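Moving the methoxy group: what to expect of compound 3

A few compounds are considered here, and "the series" means these few. Any claim that something is new, unique, unknown or untested is made for them only; others in the source may bear on it.

In a functional assay on DU-145 cells (Homo sapiens) for antiproliferative activity, read by CCK-8 assay, with a stated time of 72 h (a lower number here means a stronger inhibitor, a higher number a weaker inhibitor), compound 1 `Cc1cc(Nc2cc(N3CCN(C)CC3)nc(Nc3ccc([N+](=O)[O-])cc3)n2)n[nH]1` gives 1200 nM and compound 2 `COc1cccc(Nc2nc(Nc3cc(C)[nH]n3)cc(N3CCN(C)CC3)n2)c1` gives 2650 nM, the higher of the two numbers. Compound 3 `COc1ccc(Nc2nc(Nc3cc(C)[nH]n3)cc(N3CCN(C)CC3)n2)cc1`, not yet measured, carries 4-methoxyphenyl in place of 3-methoxyphenyl on a nitrogen on an aromatic ring. Within the data shown here, the only measured step, a 2.2-fold higher number from compound 1 to compound 2 (0.34 log units; beyond the scatter), was modest and exchanged a different group, so it bears only loosely on this change. No step beyond the scatter is therefore expected in this assay. The expected step is a 1.1-fold lower number from compound 2 to compound 3 (0.04 log units; within the scatter). Compound 3 is estimated at 2400 nM, with a range from 1000 nM to 5500 nM.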

Compound 3, half-maximal inhibitory concentration: 5050 nM
Compound 3: the middle estimate sits 2.1-fold (0.32 log units) below what was measured, within the range that was stated.
By their numbers in this assay, from the lowest: compound 1; then compounds 2 and 3 (each within the scatter of the next).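

In this assay, 4-methoxyphenyl in place of 3-methoxyphenyl on a nitrogen on an aromatic ring gives a 1.9-fold higher number from compound 2 to compound 3 (0.28 log units; within the scatter), so moving the methoxy group on this ring gives no difference that can be told from the scatter. The pair of 4-nitrophenyl and 4-methoxyphenyl compares the two groups at one site, and methoxy in place of nitro on an aromatic carbon gives a 4.2-fold higher number from compound 1 to compound 3 (0.62 log units; beyond the scatter). No measurement at hand accounts for either step. Going by these compounds, how an amine or a carboxylic acid at that site would compare with nitro and methoxy remains open. So does the place of 2-methoxyphenyl among these compounds.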